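Series notes: chloro in place of hydrogen on compound 3

The source may hold more compounds than are shown below. What is called first, only, known or untested is meant among the compounds shown, and "the series" means these compounds.

Measured in an ADME assay for permeability, using PAMPA, at pH 7.4; on this read-out lower numbers stand for lower permeability and higher numbers for higher permeability:
compound 1 `CC(C)COc1ncc(-c2cn(C)c3cc(C(=O)NS(C)(=O)=O)ccc23)cc1Cl`: 216 nm/s
compound 2 `CC(C)COc1ncc(-c2cn(C)c3cc(C(=O)NS(=O)(=O)C4CC4)c(F)cc23)cc1Cl`: 310 nm/s
compound 3 `CC(C)COc1ccc(-c2cn(C)c3cc(C(=O)NS(C)(=O)=O)c(F)cc23)cn1`: 164 nm/s

In this assay compound 3 gives 164 nm/s, which lies within the scatter of both compound 1 and compound 2, so the three values do not separate. The next compound to be measured is compound 4 `CC(C)COc1ncc(-c2cn(C)c3cc(C(=O)NS(C)(=O)=O)c(F)cc23)cc1Cl`. It differs from compound 3 by chloro in place of hydrogen on an aromatic carbon.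

Within the data shown here, no measured pair isolates this change, so the expectation rests on indirect evidence. Compound 1 at 216 nm/s and compound 2 at 310 nm/s both carry the chloro group, but each also differs from compound 4 elsewhere. A small upward move is therefore expected, with nothing to suggest a large one. The expected change in this assay is a 1.4-fold higher number from compound 3 to compound 4 (0.15 log units; within the scatter), an estimated step that stays within the scatter. Compound 4 is estimated at 230 nm/s, with an expected range of 130 nm/s to 400 nm/s.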

Compound 4, apparent permeability: 205 nm/s
Compound 4: the middle estimate sits 1.1-fold (0.05 log units) above what was measured; the range from low to high includes it.
By their numbers in this assay, from the lowest: compounds 3, 4, 1 and 2 (each within the scatter of the next).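

In this assay, chloro in place of hydrogen on an aromatic carbon, ortho to the isobutoxy group and two atoms from the ring nitrogen, can now be read as a single change, and it gives a 1.3-fold higher number from compound 3 to compound 4 (0.10 log units; within the scatter), so hydrogen and chloro do not separate at this position. The two other single changes read alike: methyl in place of cyclopropyl on a sulfonyl sulfur gives a 1.5-fold lower number from compound 2 to compound 4 (0.18 log units; within the scatter), and adding a fluoro group gives a 1.1-fold lower number from compound 1 to compound 4 (0.02 log units; within the scatter), so neither separates the compounds. No supporting measurement bears on these results.

Open, on these data alone, is whether a nitrile or an amine at this position would separate from chloro in this assay. Also open, as far as these compounds go, is whether a longer chain in place of the isobutoxy group would do so.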